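The compounds below may be only part of what the source reports. "The series", "measured", "known", "first", "only" and "open" are said of these compounds alone.

Compound 1 `NC(=S)N1Nc2onc(-c3ccccc3)c2C1c1ccc(Cl)cc1` carries a thiourea-like end on the shared core. In an ADME assay on a cell-free system (plasma, Rattus norvegicus) for metabolic stability (a higher number here means that the compound lasts longer, a lower number that the compound disappears faster), compound 1 gives 2.2 h. Compound 2 `Cc1nc(N2Nc3onc(-c4ccccc4)c3C2c2ccc(Cl)cc2)sc1/N=N/c1ccccc1` replaces that end with a larger, azo-bearing thiazole arm, and in this assay compound 2 gives 4.42 h. The two numbers lie within the usual scatter of each other, so compound 2 cannot be set apart from compound 1 on these measurements alone.

Compound 3 `Cc1ccc(/N=N/c2sc(N3Nc4onc(-c5ccccc5)c4C3c3ccc(Cl)cc3)nc2C)cc1` differs from compound 2 by methyl in place of hydrogen on an aromatic carbon. Among the measured compounds shown here, no measured pair shows what this change does, so the expectation rests on the picture so far, where even a much larger swap did not move the numbers beyond the scatter. The expected step from compound 2 to compound 3 is small and without clear direction, a 1.0-fold lower number from compound 2 to compound 3 (0.00 log units; within the scatter). For compound 3 the half-life in this assay is estimated at 4.4 h, within a range from 2.2 h to 8.8 h.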

Compound 3, half-life: 5.72 h
Beside the measured number, compound 3's estimate is 1.3-fold (0.11 log units) below it; the range from low to high includes it.
By their numbers in this assay, from the lowest: compounds 1, 2 and 3 (each within the scatter of the next, the first and the last beyond it).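

Phenyl to 4-methylphenyl is the only change in one place among the compounds shown, and in this assay it gives a 1.3-fold higher number from compound 2 to compound 3 (0.11 log units; within the scatter), the first direct reading for this position. On an aromatic carbon para to a large group, methyl in place of hydrogen therefore makes no difference that can be told from the scatter of repeated measurements. No measurement is available to explain this result.

From the compounds shown here alone, whether an amine, a carboxylic acid or a longer chain at this same position would move the half-life beyond the scatter remains open. Also open, going by these compounds, is what a single change elsewhere on the shared core would do in this assay, since one small step at one position cannot answer that.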